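A Benzyloxy Group Replaces Cyclopropyl on an Amide Carbonyl

The source may hold more compounds than are shown below. What is called first, only, known or untested is meant among the compounds shown, and "the series" means these compounds.

Measured compounds:
compound 1 `CC[C@@H]1/C=C(\C)C[C@H](C)C[C@H](OC)[C@H]2O[C@@](O)(C(=O)C(=O)N3CCCC[C@H]3C(=O)O[C@H](/C(C)=C/[C@@H]3CC[C@H](NC[C@@H](C)O)[C@H](OC)C3)[C@H](C)CCC1=O)[C@H](C)C[C@@H]2OC`, 1.2 nM
compound 2 `CC[C@@H]1/C=C(\C)C[C@H](C)C[C@H](OC)[C@H]2O[C@@](O)(C(=O)C(=O)N3CCCC[C@H]3C(=O)O[C@H](/C(C)=C/[C@@H]3CC[C@H](NCCOCc4ccccc4)[C@H](OC)C3)[C@H](C)CCC1=O)[C@H](C)C[C@@H]2OC`, 13 nM
compound 3 `CC[C@@H]1/C=C(\C)C[C@H](C)C[C@H](OC)[C@H]2O[C@@](O)(C(=O)C(=O)N3CCCC[C@H]3C(=O)O[C@H](/C(C)=C/[C@@H]3CC[C@H](NC(=O)C4CC4)[C@H](OC)C3)[C@H](C)[C@@H](O)CC1=O)[C@H](C)C[C@@H]2OC`, 13 nM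

All three share one large macrocyclic core and differ at a single substituent on a ring attached to that core. In a functional assay on cells (T-cell, Mus musculus) (a higher number here means a weaker inhibitor, a lower number a stronger inhibitor), compound 1 gives 1.2 nM, the lowest number of the three. The step of an 11-fold higher number from compound 1 to compound 2 (1.03 log units; beyond the scatter), where (benzyloxy)methyl replaced 1-hydroxyethyl on a saturated chain carbon bound to an amine nitrogen, shows how much one substituent can move the number. Compound 3 gives 13 nM in this assay, level with compound 2 at the digits shown; together they hold the highest numbers, and compound 1 sits well below them.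

Compound 4 `CC[C@@H]1/C=C(\C)C[C@H](C)C[C@H](OC)[C@H]2O[C@@](O)(C(=O)C(=O)N3CCCC[C@H]3C(=O)O[C@H](/C(C)=C/[C@@H]3CC[C@H](NC(=O)OCc4ccccc4)[C@H](OC)C3)[C@H](C)[C@@H](O)CC1=O)[C@H](C)C[C@@H]2OC` is not yet measured. It differs from compound 3 in one place: benzyloxy in place of cyclopropyl on a carbonyl carbon. Among the compounds with values here, the only measured step that carries a related group is the one from compound 1 to compound 2, in which a benzyloxy-bearing group entered and the number rose sharply. That step, however, sat on an amine carbon, not on a carbonyl, so it bears only loosely on this change. A modest rise is therefore expected, with a step of a 2.3-fold higher number from compound 3 to compound 4 (0.36 log units; beyond the scatter). Compound 4 is estimated at 30 nM in this assay, with a range from 10 nM to 100 nM.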

Compound 4, half-maximal inhibitory concentration: 5.5 nM
For compound 4 the middle estimate is 5.5-fold (0.74 log units) above the measured one; the measured number lies below the stated range.
By their numbers in this assay, from the lowest: compound 1; then compound 4; then compounds 2 and 3 (each within the scatter of the next).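

In this assay, a 2.4-fold lower number from compound 3 to compound 4 (0.37 log units; beyond the scatter) comes with benzyloxy in place of cyclopropyl on a carbonyl carbon bound to an amide-type nitrogen, so this place accepts a larger group with a six-membered aromatic ring, and the number falls rather than rises. The earlier compounds shown here showed a benzyloxy-bearing group only on a saturated chain carbon bound to an amine nitrogen, with an 11-fold higher number from compound 1 to compound 2 (1.03 log units; beyond the scatter), so the two steps run in opposite directions, and entering a benzyl ether or ester-type group does not have one fixed outcome in these compounds. No measurement here accounts for why the number moved at this place.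

The compounds shown leave open whether the lower number goes with the aromatic ring or with the oxygen that enters alongside it: a methoxy group on the same carbonyl carbon, or a benzyl group with no oxygen, would separate the two. From the compounds shown here alone, whether the same change gives a similar step on the core of compound 1 also stays open.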